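The compounds below may be only part of what the source reports. "The series", "measured", "known", "first", "only" and "open" are said of these compounds alone.

Measured so far:
compound 1 `O=C1COc2ccc(-c3cccc(NS(=O)(=O)c4ccc(F)cc4)c3)cc2N1c1ccc(Cl)cc1` gives 35000 nM
compound 2 `Cc1ccc(N2C(=O)COc3ccc(-c4cnc(Cl)c(NS(=O)(=O)c5ccc(F)cc5)c4)cc32)cc1` gives 32300 nM

Both values come from a functional assay on HeLa cells (Homo sapiens) for antiproliferative activity, read by MTT assay, with a stated time of 72 h; on this read-out higher numbers stand for weaker inhibition and lower numbers for stronger inhibition. Compound 1 gives 35000 nM there and compound 2 gives 32300 nM in the same test, so the two lie within the usual scatter of each other and cannot be ranked. Going by the values given here, compound 1 therefore stands level with the only other measured compound.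

Compound 3 `O=C1COc2ccc(-c3cccc(NS(=O)(=O)c4ccc(F)cc4)c3)cc2N1C1CCCCC1` keeps the core of compound 1 and has cyclohexyl in place of 4-chlorophenyl on an amide-type nitrogen in a ring. Among the compounds with values here, no measured pair shows what this exchange does in this assay, and compound 2 differs from compound 1 in more than one place, so it gives no direct guide. The expectation therefore rests on the closeness of the two measured values, and no step beyond the scatter is expected, in either direction. The estimated change is a 1.2-fold lower number from compound 1 to compound 3 (0.07 log units; within the scatter) and carries wide uncertainty. For compound 3 the expected value is 30000 nM with an estimated range from 12000 nM to 65000 nM at its two ends.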

Compound 3, half-maximal inhibitory concentration: 10800 nM
Beside the measured number, compound 3's estimate is 2.8-fold (0.44 log units) above it; measured number below the stated range.
By their numbers in this assay, from the lowest: compound 3; then compounds 2 and 1 (each within the scatter of the next).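

In this assay the amide-type nitrogen in a ring proves not to be indifferent to what it carries: cyclohexyl in place of 4-chlorophenyl gives the first step shown beyond the scatter (a 3.2-fold lower number from compound 1 to compound 3 (0.51 log units; beyond the scatter)), and the step is modest in size. The exchange removes a six-membered aromatic ring of carbon only, together with its chlorine, and brings in a six-membered non-aromatic ring of carbon only. The counts of hydrogen-bond donors and acceptors stay the same, so the shift in the number comes with no change in either count. No measurement at hand bears on why the number falls, and this single step cannot separate the loss of the chlorine from the loss of the aromatic ring.

From the compounds shown here alone, it remains open how an unsubstituted phenyl, a cyclopentyl ring or an open n-butyl chain on this nitrogen would compare with cyclohexyl and 4-chlorophenyl. Also open, going by these compounds, are whether a piperidin-4-yl ring would keep the lower number and whether the same exchange would have a similar effect on the core of compound 2.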